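Replacing the Nitrogen Hydrogen of Compound 1 with an Oxazolylmethyl

This account rests on a few compounds, and the source may have more. Where it says the series, first, only, none or still open, it means among the compounds named here.

Compound 1 `CC1(C)Oc2ccc(C#N)cc2[C@H](Nc2ccccc2)[C@H]1O`: 1200 nM
Compound 2 `CC1(C)Oc2ccc(C#N)cc2[C@H](N(CC(=O)O)c2ccccc2)[C@H]1O`: > 100000 nM, a limit of the assay rather than a number

Going by the values given here, in a functional assay (aorta) with Rattus norvegicus as the target (a lower number here means a stronger inhibitor, a higher number a weaker inhibitor), compound 1 gives 1200 nM, the only number recorded here. The value of compound 2 is a limit of the assay rather than a number. Compound 3 `CC1(C)Oc2ccc(C#N)cc2[C@H](N(Cc2ncco2)c2ccccc2)[C@H]1O` differs from compound 1 by (1,3-oxazol-2-yl)methyl in place of hydrogen on a nitrogen on an aromatic ring. Among the compounds with values here, the one measured step that bears on this change is an at least 83-fold higher number from compound 1 to compound 2 (1.92 log units; beyond the scatter), a step that ran into (the limit of > 100000 nM in this assay, at which 1 of the 2 values shown sits). A substituent placed on this nitrogen is therefore expected to raise the number beyond the scatter, though the size of that rise is uncertain. Compound 3 is estimated at 10000 nM, with a range from 2000 nM to 80000 nM. This estimate means an 8.3-fold higher number from compound 1 to compound 3 (0.92 log units; beyond the scatter).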

Compound 3, half-maximal inhibitory concentration: > 30000 nM
Compound 3 ended at the assay's limit; the forecaster's own chance of this, stated with the estimate: 20%; middle value at least 3.0-fold (0.47 log units) away from the limit.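

In this assay, (1,3-oxazol-2-yl)methyl in place of hydrogen on this nitrogen gives an at least 25-fold higher number from compound 1 to compound 3 (1.39 log units; beyond the scatter). The large rise seen with the carboxymethyl group of compound 2 therefore recurs with a group that has no net charge and no hydrogen-bond donors. The value of compound 3, > 30000 nM, is a limit of the assay and not a number: the limit of > 30000 nM in this assay, at which 1 of the 3 values shown sits.

Compound 2 and compound 3 both stand at limits, and the step between them cannot be read. On these data alone, whether a single methyl or a simple amine on this nitrogen would keep the number close to that of compound 1 stays open.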